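The compounds below may be only part of what the source reports. "The series", "measured", "known", "first", "only" and "open" are said of these compounds alone.

Compound 1, with the structure `C#CCNC1CCc2c(SCCc3cccc(Br)c3)cccc21`, is the reference point of this small set. In an ADME assay on isolated protein for inhibition of Amine oxidase [flavin-containing] B (Homo sapiens) (on this read-out lower numbers stand for stronger inhibition and higher numbers for weaker inhibition), compound 1 gives 620 nM. Compound 2, with the structure `C#CCNC1CCc2c(SCCc3ccc(C(F)(F)F)cc3)cccc21`, is the second measured member of the set, and in this assay compound 2 gives 8780 nM. Compound 3, with the structure `C#CCNC1CCc2c(SCCc3ccc(F)c(F)c3)cccc21`, stands apart from these two: in this assay the entry for compound 3 reads "not determined" (no result reported), so it cannot be placed against compound 1 or compound 2 on the numbers shown.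

Compound 4, with the structure `C#CCNC1CCc2c(SCCc3ccc(Br)cc3)cccc21`, has not yet been measured. It differs from compound 3 in one place: 4-bromophenyl in place of 3,4-difluorophenyl on a saturated chain carbon, two bonds along the chain from a sulfur. For the measured compounds named here, since compound 3 carries no number, no step from compound 3 to compound 4 can be computed, and the expectation for compound 4 must rest on the two measured compounds alone. Compound 4 shares the bromine of compound 1, which gives 620 nM, but places it on the ring as the trifluoromethyl of compound 2 is placed, and compound 2 gives 8780 nM. On that basis compound 4 is expected to fall somewhere between those two points, at an estimated 2000 nM, with a range from 500 nM to 8000 nM.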

Compound 4, half-maximal inhibitory concentration: 1250 nM
Compound 4: the middle estimate sits 1.6-fold (0.20 log units) above what was measured, and the stated range covers the measured number.
By their numbers in this assay, from the lowest: compounds 1 and 4 (each within the scatter of the next); then compound 2.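

In this assay, bromo in place of trifluoromethyl on an aromatic carbon gives a 7.0-fold lower number from compound 2 to compound 4 (0.85 log units; beyond the scatter), so the group carried on this ring matters here, a point that compound 1 and compound 2 alone could not separate from where each group sits. The other change, 4-bromophenyl in place of 3-bromophenyl on the saturated chain carbon, gives a 2.0-fold higher number from compound 1 to compound 4 (0.30 log units; within the scatter), so these two bromophenyl compounds cannot be told apart in this read-out. Among these compounds, then, the large gap between compound 1 and compound 2 goes with the change from bromo to trifluoromethyl and not with the placement of the bromine.

As far as these compounds go, compound 3 carries no number, so the step to compound 4 cannot be read, and it remains open how 3,4-difluorophenyl compares with either bromophenyl group, or how an unsubstituted phenyl, a 4-chlorophenyl or a 4-methoxyphenyl would fall at this place. Nothing shown here bears on why bromo and trifluoromethyl differ as they do, or on why the two bromophenyl compounds stay so close.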